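This account rests on a few compounds, and the source may have more. Where it says the series, first, only, none or still open, it means among the compounds named here.

Measured compounds in a functional assay on HOS-TE85 cells (Homo sapiens) for inhibition, read by CCK-8 assay, with a stated time of 72 h; on this read-out higher numbers stand for weaker inhibition and lower numbers for stronger inhibition:
- compound 1 `COc1ccccc1N1C(=O)CSC1c1cccc(C(=O)NCCCCn2cccn2)c1` gives 91.7 nM
- compound 2 `C#Cc1cccc(N2C(=O)CSC2c2cccc(C(=O)NCCCCc3ccccc3)c2)c1` gives 149 nM
- compound 3 `COc1ccccc1N1C(=O)CSC1C(=O)NCCCCc1ccccc1` gives > 1000 nM, which is a limit of the assay rather than a number

Of the two numbers in this assay, compound 2 is the higher, with compound 1 as its nearest neighbour; the gap between compound 1 and compound 2 lies within the scatter, so the two cannot be told apart on these data. The value of compound 3 is a limit, noted in the limit of > 1000 nM in this assay, at which 1 of the 3 values shown sits, and stands apart from both numbers.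

The unmeasured compound is compound 4 `COc1ccc(N2C(=O)CSC2c2cccc(C(=O)NCCCCc3ccccc3)c2)c(OC)c1`, which is reached from compound 2 by a single change: 2,4-dimethoxyphenyl in place of 3-ethynylphenyl on an amide-type nitrogen in a ring. Among the compounds with values here, no step between measured compounds stands on record, so the size of this change in this assay can only be expected, not read off. Compound 1 carries a methoxy-bearing aryl group at the same amide-type nitrogen and gives 91.7 nM, which suggests that a methoxy-substituted ring there is tolerated.

On that basis the step of a 1.0-fold higher number from compound 2 to compound 4 (0.00 log units; within the scatter) is expected to be small, no larger than the scatter, in either direction. Compound 4 is therefore estimated at 150 nM, with a range from 60 nM to 400 nM.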

Compound 4, half-maximal inhibitory concentration: 90.4 nM
Compound 4: middle estimate off by 1.7-fold (0.22 log units), on the high side; the range from low to high includes it.
By their numbers in this assay, from the lowest: compounds 4, 1 and 2 (each within the scatter of the next). At a limit, above all of these: compound 3.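

In this assay, within the data shown here, the step of a 1.6-fold lower number from compound 2 to compound 4 (0.22 log units; within the scatter) is the first direct reading at the amide-type nitrogen in the ring, where the earlier compounds offered no pair differing in this one place. It shows that, with the rest of compound 2 held constant, this position accepts two differently built aryl groups without a difference that can be told from the scatter: 3-ethynylphenyl, with its triple bond and no hydrogen-bond acceptors, and 2,4-dimethoxyphenyl, with 2 hydrogen-bond acceptors. Nothing measured here gives a cause for this step or bears on one.

As far as these compounds go, whether the position also accepts a group that is not an aryl ring, such as a cyclohexyl or a plain methyl, or an aryl ring carrying an amine or a carboxylic acid, remains open. Also open, from the compounds shown here alone, is whether the same exchange would read alike with the amide side chain of compound 1 in place of that of compound 2.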